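Dropping the Chloro Group from Compound 1

The source may hold more compounds than are shown below. What is called first, only, known or untested is meant among the compounds shown, and "the series" means these compounds.

Going by the values given here, compound 1 `Cc1nnc(SCc2coc3ccc(Cl)cc3c2=O)s1` is the only member of this small set with a measured number in a functional assay on HEp-2 cells (Homo sapiens) for cytotoxicity, read by MTT assay, with a stated time of 72 h (a lower number here means a stronger inhibitor, a higher number a weaker inhibitor), where compound 1 gives 4200 nM. Compound 2 `Cc1nnc(SCc2cc(=O)c3ccccc3o2)o1` reaches only the assay limit, giving > 25000 nM in this assay. Compound 3 `Cc1cc(C)n2nc(SCc3cc(=O)c4ccccc4o3)nc2n1` likewise stops at the limit, with > 25000 nM in this assay. Among the compounds with values here, two of the three values therefore sit at the limit of > 25000 nM in this assay, at which 2 of the 3 values shown sit, and no step between measured compounds is available. Compound 4 `Cc1nnc(SCc2coc3ccccc3c2=O)s1` differs from compound 1 by hydrogen in place of chloro on an aromatic carbon. Within the data shown here, with no comparable step to lean on, a modest weakening is expected, so the expected 2.1-fold higher number from compound 1 to compound 4 (0.33 log units; beyond the scatter) lies near the edge of the scatter. Compound 4 is therefore estimated at 9000 nM, within 3000 nM to 25000 nM in this assay.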

Compound 4, half-maximal inhibitory concentration: 2900 nM
Compound 4: middle estimate off by 3.1-fold (0.49 log units), on the high side; measured number below the stated range.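

Replacing the chloro with hydrogen gives a 1.4-fold lower number from compound 1 to compound 4 (0.16 log units; within the scatter) in this assay. Going by these compounds alone, this is the first comparison in the set that changes one place only, and it shows that the chloro on this aromatic carbon, para to a fused ring, is not needed for the activity of compound 1 in this test. Nothing measured here explains the result.

Going by these compounds, whether an amine or a carboxylic acid on this carbon would move the number beyond the scatter stays open. Compound 2 and compound 3 stop at a limit and differ from compound 4 in more than one place, so they offer no comparison.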